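The compounds below may be only part of what the source reports. "The series", "measured", "known", "first", "only" and "open" are said of these compounds alone.

Measured so far:
Compound 1 `CC1CCCCN1C(=S)SCc1ccc(C(=O)Nc2ccccc2N)cc1` gives 64.4% in a functional assay on MGC-803 cells (Homo sapiens) for antiproliferative activity, read by CCK-8 assay, with a stated time of 72 h, tested at 2 uM; a higher number here means a stronger effect of the compound at the concentration tested, a lower number a weaker effect.
Compound 2 `CC1CCN(C(=S)SCc2ccc(C(=O)Nc3ccccc3N)cc2)CC1` gives 28.1% in this assay.

Among the compounds with values here, compound 2 holds the lower of the two numbers available; the single measured step, a number 36.3 percentage points lower from compound 1 to compound 2 (beyond the scatter), separates it from compound 1 and lies beyond the scatter. The unmeasured compound 3 `CN1CCN(C(=S)SCc2ccc(C(=O)Nc3ccccc3N)cc2)CC1` differs from compound 2 in one place: 4-methylpiperazin-1-yl in place of 4-methylpiperidin-1-yl on a thiocarbonyl carbon. Within the data shown here, the one measured step compared two methylpiperidinyl groups with each other and so does not test the present change; no measured pair speaks to it directly. The data therefore give no firm direction, and any expectation must be loose. Compound 3 is expected to show a step of a number 6.9 percentage points higher from compound 2 to compound 3 (within the scatter) from compound 2, with a range wide enough to admit movement either way. Compound 3 is estimated at 35% in this assay, between 10% and 65%.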

Compound 3, a percentage reported as inhibition, at one concentration (the size of the read-out at that concentration, not a potency): 29.6%
The estimate for compound 3 lay 5.4 percentage points above the measured number; the measured number falls inside the stated range.
By their numbers in this assay, from the lowest: compounds 2 and 3 (each within the scatter of the next); then compound 1.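

In this assay the exchange of 4-methylpiperidin-1-yl for 4-methylpiperazin-1-yl on a thiocarbonyl carbon gives a number 1.5 percentage points higher from compound 2 to compound 3 (within the scatter) and so shows that, at this place, the second ring nitrogen with its hydrogen-bond acceptor leaves the read-out within the scatter. The change from the 2-methylpiperidin-1-yl group gives a number 34.8 percentage points lower from compound 1 to compound 3 (beyond the scatter) and so leaves compound 1 apart from both compounds that carry a 4-methyl ring, whichever ring atom stands opposite the attachment. No measurement is at hand that explains these numbers.

The compounds shown leave open whether the higher number follows the 2-methyl group itself, which a 3-methylpiperidin-1-yl, an unsubstituted piperidin-1-yl or a 2-methylpiperazin-1-yl group could test. They also leave open how a morpholin-4-yl or an open-chain diethylamino group would read at this place.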